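A few compounds are considered here, and "the series" means these few. Any claim that something is new, unique, unknown or untested is made for them only; others in the source may bear on it.

Measured so far in this series:

compound 1, `C=C1C[C@]23C[C@@]1(O)CC[C@H]2c1ccc(OS(=O)(=O)c2ccc(C)cc2)c(C)c1[C@@H]3Cn1cc(-c2ccc(F)cc2)nn1`: > 20000 nM
compound 2, `C=C1C[C@]23C[C@@]1(O)CC[C@H]2c1ccc(O)c(C)c1[C@@H]3Cn1cc(-c2ccc(F)cc2)nn1`: > 20000 nM
compound 3, `Cc1ccc(-c2cn(C[C@H]3c4c(ccc(O)c4C)[C@@H]4CC[C@@]5(C)C[C@]43CC5=O)nn2)cc1`: > 20000 nM

All three results come from a functional assay on SW480 cells (Homo sapiens) for cytotoxicity, read by MTT assay, with a stated time of 4 days; a lower number here means a stronger inhibitor, a higher number a weaker inhibitor. In this assay compound 2 gives > 20000 nM, which is a limit of the assay and not a number. Compound 1 gives > 20000 nM, again a limit. The change between the two is (4-methylphenyl)sulfonyl in place of hydrogen on an oxygen on an aromatic ring, and the step that the two limits leave unreadable from compound 2 to compound 1 cannot be sized, since both ends sit at the limit. Compound 3 gives > 20000 nM, once more a limit. How the core of compound 3 differs from the core of compound 2 is not broken down here.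

Compound 4, `Cc1ccc(-c2cn(C[C@H]3c4c(ccc(OS(=O)(=O)c5ccc(C)cc5)c4C)[C@@H]4CC[C@@]5(C)C[C@]43CC5=O)nn2)cc1`, is not yet measured in this assay. It differs from compound 3 by (4-methylphenyl)sulfonyl in place of hydrogen on an oxygen on an aromatic ring, the same change, at the same kind of place, as that from compound 2 to compound 1. For the measured compounds named here, the only evidence on the effect of this change is the limit of > 20000 nM in this assay, at which 3 of the 3 values shown sit, so the change has never been seen to pull a value into the readable range.

For compound 4 the step expected in this assay is a step that the limit leaves unreadable from compound 3 to compound 4, on the ground that compound 3 sits at > 20000 nM and that the same change on compound 2 left the value at the limit. Compound 4 is therefore estimated at 40000 nM, with a range from 15000 nM to 150000 nM, and most likely the assay will again report only a limit.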

Compound 4, half-maximal inhibitory concentration: > 20000 nM
Compound 4: no number, only a limit; the forecaster's own chance of this, stated with the estimate: 85%; the middle value is on the limit's open side.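

In this assay compound 4 gives > 20000 nM, which is a limit of the assay and not a number. Compound 3 also stands at a limit, so no step can be read between compound 3 and compound 4. The compounds shown leave open whether the change from hydroxy to ((4-methylphenyl)sulfonyl)oxy has any effect in this assay, and which structural change would bring a value into the readable range.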